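Dithiocarbamate analogue: chlorophenyl position step

The compounds below may be only part of what the source reports. "The series", "measured", "known", "first", "only" and "open" are said of these compounds alone.

Compounds 1 and 3 share a core and differ only as printed under (2-chlorophenyl in place of 3-chlorophenyl on a saturated chain carbon bound to an aromatic nitrogen). In a functional assay on 4T1 cells (Mus musculus) for cytotoxicity, read by MTT assay, with a stated time of 24 h (on this read-out higher numbers stand for weaker inhibition and lower numbers for stronger inhibition), compound 1 `COc1ccc(/C=C2\CN(Cc3cn(Cc4cccc(Cl)c4)nn3)C/C(=C\c3ccc(OC)cc3)C2=O)cc1` gives 56600 nM, and compound 3 `COc1ccc(/C=C2\CN(Cc3cn(Cc4ccccc4Cl)nn3)C/C(=C\c3ccc(OC)cc3)C2=O)cc1` gives 11400 nM, a step of a 5.0-fold lower number from compound 1 to compound 3 (0.70 log units; beyond the scatter). Compound 2 `COc1ccc(/C=C2\CN(C(=S)SCc3cn(Cc4cccc(Cl)c4)nn3)C/C(=C\c3ccc(OC)cc3)C2=O)cc1` carries a different core; the difference between its core and that of compound 1 is not broken down here. In this assay compound 2 gives 69700 nM, which stands within the scatter of compound 1. Compound 4 `COc1ccc(/C=C2\CN(C(=S)SCc3cn(Cc4ccccc4Cl)nn3)C/C(=C\c3ccc(OC)cc3)C2=O)cc1` is unmeasured and differs from compound 2 by 2-chlorophenyl in place of 3-chlorophenyl on a saturated chain carbon bound to an aromatic nitrogen, the same change as from compound 1 to compound 3, at the same place. Among the measured compounds shown here, compound 4 is expected to show a step of a 4.4-fold lower number from compound 2 to compound 4 (0.64 log units; beyond the scatter) from compound 2, resting on the single measured instance a 5.0-fold lower number from compound 1 to compound 3 (0.70 log units; beyond the scatter), while transfer across cores remains untested. Compound 4 is estimated at 16000 nM, between 6000 nM and 45000 nM.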

Compound 4, half-maximal inhibitory concentration: > 100000 nM
Compound 4: no number, only a limit (the forecaster's own chance of this, stated with the estimate: 5%); at least 6.2-fold (0.79 log units) between middle value and limit.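

In this assay compound 4 reads > 100000 nM, which is a limit of the assay and not a number. The change from 3-chlorophenyl to 2-chlorophenyl does not carry over as a constant step from the core of compound 1 to the core of compound 2: the same change on two cores in this assay, a 5.0-fold lower number (0.70 log units; beyond the scatter) from compound 1 to compound 3 and an at least 1.4-fold higher number (0.15 log units; that floor lies within the scatter) from compound 2 to compound 4, at least 7.1-fold (0.85 log units) apart, beyond the scatter of two such steps. Read alone, the new step is an at least 1.4-fold higher number from compound 2 to compound 4 (0.15 log units; that floor lies within the scatter), so its true size remains unknown, and a single pair on each core shows a difference between these two cores only, not a rule for the series.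

Open, on these data alone, is how the two cores compare with an unsubstituted phenyl or a fluorophenyl on a saturated chain carbon bound to an aromatic nitrogen. Also open, as far as these compounds go, is whether any such group on the core of compound 2 gives a value rather than a limit.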